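Swapping a Fluorobenzyl Arm for a Cinnamyl Arm

The compounds below may be only part of what the source reports. "The series", "measured", "known", "first", "only" and "open" are said of these compounds alone.

Compound 1 `COc1ccc(C(O)(Cc2ccc(C)cc2)c2cccc3ccccc23)c(OC)c1OC`: > 20000 nM
Compound 2 `C=CCC(O)(c1ccc(OC)c(OC)c1OC)c1cccc2ccccc12`: > 20000 nM
Compound 3 `COc1ccc(C(O)(Cc2ccc(F)cc2)c2cccc3ccccc23)c(OC)c1OC`: 5440 nM

Going by the values given here, in a functional assay on MDA-MB-231 cells (Homo sapiens) for inhibition, read by sulforhodamine B assay, with a stated time of 48 h (a lower number here means a stronger inhibitor, a higher number a weaker inhibitor), compound 3 gives the only actual number among the three. For compound 1 the value is a limit of the assay, not a number. For compound 2 the value is likewise a limit. Both limits sit at the limit of > 20000 nM in this assay, at which 2 of the 3 values shown sit.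

Compound 4 `COc1ccc(C(O)(C/C=C\c2ccccc2)c2cccc3ccccc23)c(OC)c1OC` carries the change (2-phenylethenyl in place of 4-fluorophenyl on a saturated chain carbon, two bonds along the chain from two aromatic carbons and an oxygen on a saturated carbon). Among the compounds with values here, two measured steps bear on this position: an at least 3.6-fold lower number from compound 1 to compound 3 (0.56 log units; beyond the scatter) and an at least 3.6-fold lower number from compound 2 to compound 3 (0.56 log units; beyond the scatter), so what hangs here clearly moves the read-out. Compound 2, with a small vinyl group, sat at the limit, while the fluorophenyl of compound 3 did best. The phenylethenyl of compound 4 is neither; a modest step toward a higher number is expected, a 1.7-fold higher number from compound 3 to compound 4 (0.22 log units; within the scatter), giving an estimated 9000 nM for compound 4, within 2500 nM to 30000 nM.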

Compound 4, half-maximal inhibitory concentration: 12800 nM
Beside the measured number, compound 4's estimate is 1.4-fold (0.15 log units) below it; measured number inside the range.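

In this assay, the 3-phenylprop-2-en-1-yl arm still gives a real number, but it does not match the 4-fluorobenzyl arm, with a 2.4-fold higher number from compound 3 to compound 4 (0.37 log units; beyond the scatter). The other two comparisons show an at least 1.5-fold lower number from compound 2 to compound 4 (0.19 log units; that floor lies within the scatter) and an at least 1.5-fold lower number from compound 1 to compound 4 (0.19 log units; that floor lies within the scatter), so neither floor establishes a real gain. Compound 1 and compound 2 each stand at a limit, not a number: the limit of > 20000 nM in this assay, at which 2 of the 4 values shown sit.

The compounds shown leave open whether the double bond itself matters, which a saturated 3-phenylpropyl arm could test. Going by these compounds, how a 4-aminobenzyl arm would read at this position also remains open.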